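Replacing an arylethyl acyl group with cyclopropylmethyl

This account rests on a few compounds, and the source may have more. Where it says the series, first, only, none or still open, it means among the compounds named here.

Three compounds have been measured in an assay on THP-1 cells for displacement of a labelled ligand from C-C chemokine receptor type 1 (Homo sapiens); on this read-out higher numbers stand for weaker inhibition and lower numbers for stronger inhibition:

Compound 1 `Cc1ccc(CCC(=O)N[C@@H](C(=O)N2CCC(c3ccc(Cl)cc3)CC2)C(C)C)cc1` gives 105 nM.
Compound 2 `CC(C)[C@@H](NC(=O)C1CCCC1)C(=O)N1CCC(c2ccc(Cl)cc2)CC1` gives 70 nM.
Compound 3 `Cc1cccc(CCC(=O)N[C@@H](C(=O)N2CCC(c3ccc(Cl)cc3)CC2)C(C)C)c1` gives 22 nM.

Compound 3 stands lowest of the three; the step of a 3.2-fold lower number from compound 2 to compound 3 (0.50 log units; beyond the scatter) and the step of a 4.8-fold lower number from compound 1 to compound 3 (0.68 log units; beyond the scatter) both lie beyond the scatter, so compound 3 is the strongest inhibitor in this set. Compound 4 `CC(C)[C@@H](NC(=O)CC1CC1)C(=O)N1CCC(c2ccc(Cl)cc2)CC1` differs from compound 3 in one place: cyclopropyl in place of 3-methylbenzyl on a saturated chain carbon bound to a carbonyl carbon; the same difference, cut one bond further out, reads 2-(3-methylphenyl)ethyl to cyclopropylmethyl. The step that bears most directly on this is a 3.2-fold lower number from compound 2 to compound 3 (0.50 log units; beyond the scatter), where a cyclopentyl acyl group in place of the arylethyl group on the carbonyl carbon gave a higher number; compound 4 carries an even smaller saturated group. The step of a 1.5-fold lower number from compound 1 to compound 2 (0.18 log units; within the scatter) shows that two groups lacking the 3-methylphenyl ring gave numbers within the scatter of each other. A modest rise in this assay is therefore expected, a 5.5-fold higher number from compound 3 to compound 4 (0.74 log units; beyond the scatter). Compound 4 is estimated at 120 nM, with a range from 40 nM to 400 nM.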

Compound 4, half-maximal inhibitory concentration: 46 nM
Compound 4: middle estimate off by 2.6-fold (0.42 log units), on the high side; low and high end bracket the measured number.
By their numbers in this assay, from the lowest: compound 3; then compounds 4, 2 and 1 (each within the scatter of the next, the first and the last beyond it).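

In this assay the result places cyclopropylmethyl level with cyclopentyl on the carbonyl carbon (a 1.5-fold lower number from compound 2 to compound 4 (0.18 log units; within the scatter)), so these two saturated groups cannot be told apart at this position. The arylethyl groups fall on opposite sides of compound 4: the change away from the 3-methylbenzyl portion raises the number (a 2.1-fold higher number from compound 3 to compound 4 (0.32 log units; beyond the scatter)), whereas the same change away from the 4-methylbenzyl portion lowers it (a 2.3-fold lower number from compound 1 to compound 4 (0.36 log units; beyond the scatter)). The aryl ring therefore brings no gain of its own in this set, and the outcome depends on which methylphenyl group is present, though nothing available explains this reversal.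

Going by these compounds, it remains open how an unsubstituted phenyl ring or a methoxy group in place of the methyl would compare at this position. A longer saturated chain on the carbonyl carbon, or an amine on the small group, is also untested in the compounds shown here.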